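A few compounds are considered here, and "the series" means these few. Any claim that something is new, unique, unknown or untested is made for them only; others in the source may bear on it.

Measured in a functional assay with Mus musculus as the target; a lower number here means that less compound is needed, a higher number that more compound is needed for the effect:
- compound 1 `CCCn1c(=O)n(C2OC(COP(=O)(O)O)[C@@H](O)[C@H]2O)c2nc(N)nc(O)c21`: 82 uM
- compound 2 `COc1ccc(Cn2c(=O)n(C3OC(CO)[C@@H](O)[C@H]3O)c3nc(N)nc(O)c32)cc1`: 2 uM

Compound 2 holds the lower of the two numbers, beyond the scatter from compound 1. Compound 3 `CCOC(=O)Cn1c(=O)n(C2OC(CO)[C@@H](O)[C@H]2O)c2nc(N)nc(O)c21` has ethoxycarbonyl in place of 4-methoxyphenyl on a saturated chain carbon bound to an aromatic nitrogen. Among the compounds with values here, no measured step covers this change, so the expectation is tentative. A higher number is expected in this assay, with an estimated 6.0-fold higher number from compound 2 to compound 3 (0.78 log units; beyond the scatter), probably beyond the scatter. For compound 3 the estimate is 12 uM, with an expected range of 3 uM to 50 uM.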

Compound 3, concentration for half-maximal effect: 630 uM
The estimate for compound 3 lay 53-fold (1.72 log units) below the measured number; the measured number lies above the stated range.
By their numbers in this assay, from the lowest: compound 2; then compound 1; then compound 3.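

At the saturated chain carbon bound to an aromatic nitrogen, the group carried there matters strongly in this assay: ethoxycarbonyl in place of 4-methoxyphenyl gives a 320-fold higher number from compound 2 to compound 3 (2.50 log units; beyond the scatter) on an otherwise unchanged structure. This is the series' first comparison that differs in one place, and it shows that this position does not tolerate this exchange. Nothing available explains the size of this step.

As far as these compounds go, it remains open whether the step follows from the departing 4-methoxyphenyl or the entering ethoxycarbonyl. Plain phenyl or a carboxylic acid on the same carbon would help separate the two.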